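A few compounds are considered here, and "the series" means these few. Any claim that something is new, unique, unknown or untested is made for them only; others in the source may bear on it.

Of the compounds shown here, three of one shared core have been measured in a functional assay on SF-295 cells (Homo sapiens) for antiproliferative activity, with a stated time of 48 h; on this read-out higher numbers stand for weaker inhibition of growth and lower numbers for stronger inhibition of growth. Compound 1 `Cc1cc(O)c(C2=NN(c3ccc(S(N)(=O)=O)cc3)C(c3ccccc3O)C2)cc1Cl` gives 1660 nM. Compound 2 `Cc1cc(O)c(C2=NN(c3ccc(S(N)(=O)=O)cc3)C(c3ccccc3Cl)C2)cc1Cl` gives 1590 nM, and compound 3 `Cc1cc(O)c(C2=NN(c3ccc(S(N)(=O)=O)cc3)C(/C=C/c3ccccc3)C2)cc1Cl` gives 2360 nM. Compound 2 shows the smallest of the three numbers, yet the step of a 1.0-fold lower number from compound 1 to compound 2 (0.02 log units; within the scatter) and the step of a 1.5-fold higher number from compound 2 to compound 3 (0.17 log units; within the scatter) are both within the scatter, so the three compounds cannot be told apart on this read-out.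

Compound 4 `COc1ccc(C2CC(c3cc(Cl)c(C)cc3O)=NN2c2ccc(S(N)(=O)=O)cc2)c(OC)c1OC` has not yet been measured. It differs from compound 2 at a single place: 2,3,4-trimethoxyphenyl in place of 2-chlorophenyl on a saturated ring carbon. Every step already seen touches the group on that same saturated ring carbon: a 1.0-fold lower number from compound 1 to compound 2 (0.02 log units; within the scatter), a 1.4-fold higher number from compound 1 to compound 3 (0.15 log units; within the scatter) and a 1.5-fold higher number from compound 2 to compound 3 (0.17 log units; within the scatter), none of them beyond the scatter. On that basis no change beyond the scatter is expected for compound 4 in this assay, that is, a step of a 1.1-fold higher number from compound 2 to compound 4 (0.03 log units; within the scatter) is estimated. Compound 4 is therefore expected to give about 1700 nM, with a range from 800 nM to 3600 nM.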

Compound 4, concentration for 50% growth inhibition: 1800 nM
The estimate for compound 4 lay 1.1-fold (0.02 log units) below the measured number; low and high end bracket the measured number.
By their numbers in this assay, from the lowest: compounds 2, 1, 4 and 3 (each within the scatter of the next).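

In this assay the saturated ring carbon next to the ring nitrogen now also carries 2,3,4-trimethoxyphenyl, with 12 heavy atoms and 3 hydrogen-bond acceptors, where 2-chlorophenyl has 7 heavy atoms and 0 hydrogen-bond acceptors. Even so, this exchange gives a 1.1-fold higher number from compound 2 to compound 4 (0.05 log units; within the scatter) and the comparisons with the other two groups give a 1.3-fold lower number from compound 3 to compound 4 (0.12 log units; within the scatter) and a 1.1-fold higher number from compound 1 to compound 4 (0.04 log units; within the scatter) as well. A group this much larger than 2-chlorophenyl therefore leaves the read-out unmoved at this position, and all four compounds still cannot be told apart.

As far as these compounds go, whether an amine, a carboxylic acid or a longer chain on this carbon would shift the number remains open, as does any change elsewhere on the shared core. Nothing available offers a measured explanation for this flat picture.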